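Dropping a Chloro Group from an Aryl Piperazine

The source may report more compounds than this note shows. Statements on the series, on what has been measured and on what is new or still open speak of the compounds shown alone.

Going by the values given here, compound 3 `CCCn1c(=O)[nH]c2nc(-c3ccc(S(=O)(=O)N4CCN(c5ccc(Cl)cc5F)CC4)cc3)[nH]c2c1=O` gives 1.91 nM in an assay on CHO cells for displacement of a labelled ligand from adenosine receptor A2b (Homo sapiens), read by scintillation counting, with a stated time of 75 min, in the presence of a further agent that is not named here (on this read-out higher numbers stand for weaker inhibition and lower numbers for stronger inhibition), level with compound 2 `CCCn1c(=O)c2[nH]c(-c3ccc(S(=O)(=O)N4CCN(c5ccc(Cl)cc5)CC4)cc3)nc2n(C)c1=O` at 1.91 nM, the two lowest numbers of three; compound 1 `CCCn1c(=O)[nH]c2nc(-c3ccc(S(=O)(=O)N4CCN(C)CC4)cc3)[nH]c2c1=O` gives 48.2 nM, and the only counted step, a 25-fold lower number from compound 1 to compound 3 (1.40 log units; beyond the scatter), is large. Compound 4 `CCCn1c(=O)[nH]c2nc(-c3ccc(S(=O)(=O)N4CCN(c5ccccc5F)CC4)cc3)[nH]c2c1=O` differs from compound 3 by hydrogen in place of chloro on an aromatic carbon. Among the compounds with values here, no measured step touches this chloro alone: the step from compound 1 installed the whole 4-chloro-2-fluorophenyl at once, so how much of that gain rests on the chloro is unknown. A small loss, or none beyond the scatter, is expected, a 1.8-fold higher number from compound 3 to compound 4 (0.26 log units; within the scatter). Compound 4 is therefore estimated at 3.5 nM, with a range from 1.3 nM to 10 nM.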

Compound 4, inhibition constant: 3.22 nM
Compound 4: middle estimate off by 1.1-fold (0.04 log units), on the high side; the range from low to high includes it.
By their numbers in this assay, from the lowest: compounds 2, 3 and 4 (each within the scatter of the next); then compound 1.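

Replacing the chloro with hydrogen gives a 1.7-fold higher number from compound 3 to compound 4 (0.23 log units; within the scatter) in this assay, so at this place, para to a large group, the chloro can go without a change that stands out from the scatter. The 2-fluorophenyl without chloro keeps a large gain over methyl on the ring nitrogen, a 15-fold lower number from compound 1 to compound 4 (1.18 log units; beyond the scatter), so that gain does not rest on the chloro. No measurement here explains this result.

From the compounds shown here alone, what the fluoro adds by itself remains open, and a plain phenyl on that nitrogen would separate it from the ring. A methoxy or nitrile in the chloro's place also remains an open question.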